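Acylguanidine series: cyclohexyl to methylsulfanyl at the aromatic carbon

The source may report more compounds than this note shows. Statements on the series, on what has been measured and on what is new or still open speak of the compounds shown alone.

Of the compounds shown here, two have numbers so far. Compound 1 `CCCCCc1cc(C)c(C(=O)N=C(N)N)cc1S(C)(=O)=O` gives in a functional assay for inhibition of sodium/hydrogen exchanger (Oryctolagus cuniculus) (a higher number here means a weaker inhibitor, a lower number a stronger inhibitor), a value of 27 nM. Compound 2 `Cc1cc(C2CCCCC2)c(S(C)(=O)=O)cc1C(=O)N=C(N)N` gives in this assay a value of 22 nM. Among the measured compounds shown here, the single measured step, a 1.2-fold lower number from compound 1 to compound 2 (0.09 log units; within the scatter), exchanges one six-carbon group for another at the same aromatic carbon and does not move the number beyond the scatter. Compound 2 therefore holds the lower of the two numbers, but the gap to compound 1 is within the scatter, so no order between the two can be stated.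

Compound 3 `CSc1cc(C)c(C(=O)N=C(N)N)cc1S(C)(=O)=O` is not yet measured. It differs from compound 2 by methylsulfanyl in place of cyclohexyl on an aromatic carbon. The measured step bears on this only loosely: it kept the size of the group, whereas here a six-atom group gives way to a two-atom one, a change without a measured counterpart in the series. For the measured compounds named here, no measured step supports a prediction of direction, so the expectation rests on the size of the change alone; a shift beyond the scatter is plausible, with a higher number treated as more likely than a lower one.

For compound 3 the estimate in this assay is 60 nM, with a range from 15 nM to 250 nM. Relative to compound 2 this estimate means the expected step of a 2.7-fold higher number from compound 2 to compound 3 (0.44 log units; beyond the scatter).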

Compound 3, half-maximal inhibitory concentration: 6 nM
Beside the measured number, compound 3's estimate is 10-fold (1.00 log units) above it; the measured number lies below the stated range.
By their numbers in this assay, from the lowest: compound 3; then compounds 2 and 1 (each within the scatter of the next).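

Among the compounds shown here, at this aromatic carbon, ortho to a methylsulfonyl group, the number in this assay does respond to the group: the step of a 3.7-fold lower number from compound 2 to compound 3 (0.56 log units; beyond the scatter) and the step of a 4.5-fold lower number from compound 1 to compound 3 (0.65 log units; beyond the scatter) are the first to pass beyond the scatter, whereas exchanging pentyl for cyclohexyl did not. Compound 3 therefore holds the lowest number of the three, and neither pentyl nor cyclohexyl, whether open chain or ring, matches methylsulfanyl here. The change from either group alters several things at once (the heavy-atom count, the presence of sulfur and the hydrogen-bond acceptor count), and no measurement in hand ties the lower number to any one of them.

The three compounds do not separate the effect of a short group from that of the sulfur atom, a question that methyl, ethyl or methoxy at this carbon would address. From the compounds shown here alone, it also stays open how far the trend runs beyond methylsulfanyl, for instance to an amine or to a longer thioether such as ethylsulfanyl.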